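A few compounds are considered here, and "the series" means these few. Any claim that something is new, unique, unknown or untested is made for them only; others in the source may bear on it.

Of the compounds shown here, three built on a shared core have been tested in a functional assay on Raji cells (Homo sapiens) for inhibition, read by MTT assay, with a stated time of 96 h; on this read-out higher numbers stand for an effect only at larger amounts of compound and lower numbers for an effect already at smaller amounts. Compound 1 `CC(C)Cn1c(=O)n(C)c(=O)c2c1nc(Cc1cccc3ccccc13)c(=O)n2CCCCCO` gives 1420 nM. Compound 2 `CC(C)Cn1c(=O)n(C)c(=O)c2c1nc(Cc1cccc3ccccc13)c(=O)n2CCCCCCO` differs only at the far end of its hydroxyalkyl chain; in this assay compound 2 reaches > 10000 nM, which is a limit of the measurement rather than a number. Accordingly an at least 7.0-fold higher number from compound 1 to compound 2 (0.84 log units; beyond the scatter). Compound 3 `CC(C)Cn1c(=O)n(C)c(=O)c2nc(S(=O)(=O)CCCO)c(Cc3cccc4ccccc34)nc21`, which bears a (3-hydroxypropyl)sulfonyl group on the core instead, gives 3750 nM in this assay; of the two numbers available it is the highest, and its gap to compound 1 lies beyond the scatter.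

Compound 4 `CC(C)Cn1c(=O)n(C)c(=O)c2nc(-c3[nH]nnc3CCCO)c(Cc3cccc4ccccc34)nc21` has not yet been measured. The change is 4-(3-hydroxypropyl)-1H-1,2,3-triazol-5-yl in place of (3-hydroxypropyl)sulfonyl on an aromatic carbon. Among the compounds with values here, no measured step bears directly on this exchange: the only step at hand, an at least 7.0-fold higher number from compound 1 to compound 2 (0.84 log units; beyond the scatter), concerns lengthening a hydroxyalkyl chain on a ring nitrogen, not swapping a sulfonyl for a triazolyl ring, and the hydroxypropyl chain itself is kept in compound 4. Without such guidance, a step of no more than modest size in either direction is expected, so a 1.3-fold lower number from compound 3 to compound 4 (0.10 log units; within the scatter) is the estimated step. Compound 4 is therefore expected to give roughly 3000 nM, within 800 nM to 10000 nM.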

Compound 4, half-maximal effective concentration: 6020 nM
The estimate for compound 4 lay 2.0-fold (0.30 log units) below the measured number, within the range that was stated.
By their numbers in this assay, from the lowest: compound 1; then compounds 3 and 4 (each within the scatter of the next). At a limit, above all of these: compound 2.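

Replacing (3-hydroxypropyl)sulfonyl with 4-(3-hydroxypropyl)-1H-1,2,3-triazol-5-yl on this aromatic carbon gives in this assay a 1.6-fold higher number from compound 3 to compound 4 (0.21 log units; within the scatter) and so does not separate the two groups. Within the data shown here, until now, compound 3 alone spoke for this position, and the only step available concerned a hydroxyalkyl chain on a ring nitrogen. Compound 4 adds a second group here: a five-membered aromatic ring with 3 hetero atoms takes the place of a sulfonyl link, the hydroxypropyl chain is kept, and the reading stays within the usual spread of repeat measurements, though nothing measured here bears on why these two groups read so much alike.

Still open, on these data alone, is how much the chain on the triazole matters at this position, since a shorter or a longer chain could respond as sharply as the chain on the ring nitrogen did between compound 1 and compound 2, or not at all. Also open, as far as these compounds go, is what the hydroxy group at the end of the chain contributes, which an amine, a carboxylic acid or a plain propyl chain in its place would help to show.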